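From 4-Chlorophenyl to 3-Nitrophenyl on the Shared Core

The compounds below may be only part of what the source reports. "The series", "measured", "known", "first", "only" and "open" are said of these compounds alone.

In a functional assay on HeLa cells (Homo sapiens) for antiproliferative activity, read by MTT assay, with a stated time of 48 h (a lower number here means a stronger inhibitor, a higher number a weaker inhibitor), compound 1 `Oc1ccc2ccccc2c1C(Nc1nc2ccccc2s1)c1cn(-c2ccccc2)nc1-c1ccccc1` gives 17300 nM and compound 2 `Oc1ccc2ccccc2c1C(Nc1nc2ccccc2s1)c1cn(-c2ccccc2)nc1-c1cccc(Cl)c1` gives 6830 nM on the same read-out. That is a 2.5-fold lower number from compound 1 to compound 2 (0.40 log units; beyond the scatter) with chloro in place of hydrogen on an aromatic carbon, a modest step beyond the scatter. Compound 3 `COc1ccc2nc(NC(c3cn(-c4ccccc4)nc3-c3ccc(Cl)cc3)c3c(O)ccc4ccccc34)sc2c1` gives 5200 nM as its value, which lies within the scatter of compound 2 and beyond the scatter below compound 1. Compound 4 `COc1ccc2nc(NC(c3cn(-c4ccccc4)nc3-c3cccc([N+](=O)[O-])c3)c3c(O)ccc4ccccc34)sc2c1` keeps the rest of compound 3 and carries one change, (3-nitrophenyl in place of 4-chlorophenyl on an aromatic carbon), with 3-nitrophenyl in place of 4-chlorophenyl on an aromatic carbon of a five-membered aromatic ring with 2 nitrogen. Going by the values given here, no measured compound carries 3-nitrophenyl, and compounds 2 and 3 differ in more than one place, so only the chloro step bears on this change, and only indirectly. Among the compounds with values here, compound 4 gives up the chloro that came with a 2.5-fold lower number from compound 1 to compound 2 (0.40 log units; beyond the scatter) as its one measured precedent, so a slightly higher number is expected, though nothing beyond the scatter. The expected change is a 1.2-fold higher number from compound 3 to compound 4 (0.06 log units; within the scatter) as a small estimated step. In this assay the estimated value for compound 4 is 6000 nM with an expected range from 2500 nM to 14000 nM.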

Compound 4, half-maximal inhibitory concentration: 6140 nM
For compound 4 the middle estimate is 1.0-fold (0.01 log units) below the measured one, and the stated range covers the measured number.
By their numbers in this assay, from the lowest: compounds 3, 4 and 2 (each within the scatter of the next); then compound 1.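

In this assay, putting 3-nitrophenyl in place of 4-chlorophenyl gives a 1.2-fold higher number from compound 3 to compound 4 (0.07 log units; within the scatter), so the two groups cannot be told apart by this read-out when they sit on this aromatic carbon of the five-membered aromatic ring with 2 nitrogen, next to the ring nitrogen. Going by these compounds alone, until now, the only step bearing on this phenyl group was the chloro step, a 2.5-fold lower number from compound 1 to compound 2 (0.40 log units; beyond the scatter), which showed that a chloro group could go with a change beyond the scatter but not whether chlorine was needed on the core of compound 3; compound 4 shows that, in this one pair, a phenyl group without chlorine and with a larger substituent holds the number within the scatter. No measurement offered here accounts for why the two groups read alike.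

One pair cannot show whether this tolerance extends to other groups, such as an amine or a carboxylic acid carried on the same phenyl group. It also leaves open how an unsubstituted phenyl group at this position would read on the core of compound 3, which would give both compound 3 and compound 4 a direct reference.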